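The compounds below may be only part of what the source reports. "The series", "measured", "known", "first", "only" and "open" are said of these compounds alone.

Compound 1 `CN[C@H](C)C(=O)NCc1cccc(Cn2nc(NS(=O)(=O)c3ccc(Cl)s3)c3c(OC)cccc32)c1` and compound 2 `COc1cccc2c1c(NS(=O)(=O)c1ccc(Cl)s1)nn2Cc1cccc(CNC(=O)C(C)(C)N)c1` share one core and differ only in the group on the carbonyl carbon of the side chain. In an ADME assay on the whole organism (strain Beagle) for metabolic stability, with Canis familiaris (Canis lupus familiaris) as the target, at a dose of 0.5 mg/kg by the intravenous route (on this read-out higher numbers stand for a longer-lived compound and lower numbers for a shorter-lived compound), compound 1 gives 5.9 h, and compound 2 gives 2.4 h. Within the data shown here, the change between them reads a 2.5-fold lower number from compound 1 to compound 2 (0.39 log units; beyond the scatter), so compound 2 holds the lower of the two numbers, with compound 1 as its only neighbour.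

Compound 3 `COc1cccc2c1c(NS(=O)(=O)c1ccc(Cl)s1)nn2Cc1cccc(CNC(=O)[C@@H]2CCCCN2)c1` is the next member of the set. Against compound 2 the difference is piperidin-2-yl in place of 1-amino-1-methylethyl on a carbonyl carbon. Among the measured compounds shown here, the one measured step that bears on this place is a 2.5-fold lower number from compound 1 to compound 2 (0.39 log units; beyond the scatter), a modest move that came from exchanging one small amine-bearing group for another on the same carbonyl carbon. For the measured compounds named here, no measured pair shows a ring entering at this position, so the direction of the new step is open; its size is expected to stay modest, as the single precedent was.

On that basis compound 3 is estimated to give 3.5 h, within 1.5 h to 8 h, which would mean an expected 1.5-fold higher number from compound 2 to compound 3 (0.16 log units; within the scatter).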

Compound 3, half-life in the Canis familiaris assay: 0.95 h
Estimate against measurement, compound 3: 3.7-fold (0.57 log units) above; measured number below the stated range.
By their numbers in the Canis familiaris assay, from the lowest: compound 3; then compound 2; then compound 1.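

In the Canis familiaris assay, the first ring to enter on this carbonyl carbon takes the number down, not up: piperidin-2-yl in place of 1-amino-1-methylethyl gives a 2.5-fold lower number from compound 2 to compound 3 (0.40 log units; beyond the scatter), a move of about the same size as the earlier step between the two open-chain groups, a 2.5-fold lower number from compound 1 to compound 2 (0.39 log units; beyond the scatter). Set against 1-(methylamino)ethyl, the same ring gives a 6.2-fold lower number from compound 1 to compound 3 (0.79 log units; beyond the scatter), so the three groups now form an order with every step beyond the scatter, and the half-life at this position proves sensitive to changes in a single small amine-bearing group. The measurements shown do not bear on why the half-life falls with this ring.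

In a physicochemical assay for solubility, read by chemiluminescence, measured as kinetic solubility (a lower number here means a less soluble compound, a higher number a more soluble compound), compound 2 gives >= 180 ug/mL, which is a limit of the assay. In the physicochemical assay compound 3 gives >= 220 ug/mL, which is also a limit of the assay. From the compounds shown here alone, the step from compound 2 to compound 3 cannot be read, as both values are limits of the assay, so any difference in solubility between the two stays unknown. Also open, going by these compounds, is how a pyrrolidin-2-yl group or the mirror-image piperidin-2-yl on this carbonyl carbon would stand in the Canis familiaris assay, and so whether the fall follows the ring, its size or its stereocentre.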